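This account rests on a few compounds, and the source may have more. Where it says the series, first, only, none or still open, it means among the compounds named here.

Measured so far:
compound 1 `COc1cc(/C=C/C(=O)C2=C(/C=C/c3ccc(O)c(OC)c3)NC(=O)NC2c2ccccc2)ccc1O` with 31%
compound 2 `COc1cc(/C=C/C(=O)C2=C(/C=C/c3ccc(O)c(OC)c3)NC(=O)NC2c2ccccc2O)ccc1O` with 80.9%
compound 3 `COc1cc(/C=C/C(=O)C2=C(/C=C/c3ccc(O)c(OC)c3)NC(=O)NC2c2ccc(O)cc2)ccc1O` with 80.1%

These numbers come from a functional assay, with a stated time of 20 min, tested at 20 uM; on this read-out lower numbers stand for a weaker effect and higher numbers for a stronger effect at the one concentration tested. Compound 3 stands second highest of the three, since a number 0.8 percentage points lower from compound 2 to compound 3 (within the scatter) while a number 49.1 percentage points higher from compound 1 to compound 3 (beyond the scatter). Compound 4 `COc1cc(/C=C/C(=O)C2=C(/C=C/c3ccc(O)c(OC)c3)NC(=O)NC2c2c(Cl)cccc2Cl)ccc1O` differs from compound 3 in one place: 2,6-dichlorophenyl in place of 4-hydroxyphenyl on a saturated ring carbon. Within the data shown here, three steps bear on it. The hydroxy gave large gains, a number 49.9 percentage points higher from compound 1 to compound 2 (beyond the scatter) and a number 49.1 percentage points higher from compound 1 to compound 3 (beyond the scatter), whereas a number 0.8 percentage points lower from compound 2 to compound 3 (within the scatter), so the hydroxy, not where it sits, carried the gain. Among the measured compounds shown here, compound 4 has no hydroxy, and no compound bearing chlorine has been measured. Because a number 49.1 percentage points higher from compound 1 to compound 3 (beyond the scatter) rested on the hydroxy that compound 4 lacks, a fall back toward compound 1 is expected. For compound 4 the estimate is 40%, between 18% and 72%, which would mean an expected a number 40.1 percentage points lower from compound 3 to compound 4 (beyond the scatter).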

Compound 4, a percentage reported as activity, at one concentration (the size of the read-out at that concentration, not a potency): 33%
The estimate for compound 4 lay 7 percentage points above the measured number; the range from low to high includes it.
By their numbers in this assay, from the lowest: compounds 1 and 4 (each within the scatter of the next); then compounds 3 and 2 (each within the scatter of the next).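

In this assay, two chlorines on the phenyl group at this saturated ring carbon did not replace what the hydroxy had provided: there is a number 47.1 percentage points lower from compound 3 to compound 4 (beyond the scatter) and a number 47.9 percentage points lower from compound 2 to compound 4 (beyond the scatter), while there is a number 2 percentage points higher from compound 1 to compound 4 (within the scatter), leaving compound 4 level with the plain phenyl of compound 1. Substitution on this phenyl group therefore does not by itself raise the read-out, since only the hydroxy-bearing compound 2 and compound 3 stand high. No evidence at hand accounts for this difference.

From the compounds shown here alone, whether a methoxy or an amino group on this phenyl group would behave like the hydroxy or like hydrogen remains open. So does whether a single chlorine would match the 2,6-dichlorophenyl group.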